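Chloro for trifluoromethyl: from compound 3 to compound 4

This account rests on a few compounds, and the source may have more. Where it says the series, first, only, none or still open, it means among the compounds named here.

Three compounds of the series have numbers in a functional assay on K562 cells (Homo sapiens) for inhibition, read by sulforhodamine B assay, with a stated time of 48 h, tested at 0.01 uM; on this read-out lower numbers stand for a stronger effect and higher numbers for a weaker effect at the one concentration tested. Compound 1 `O=C(Nc1cccc(-n2cc(-c3ccncc3)c(-c3cc(O)cc(Cl)c3)n2)c1)Nc1ccc(Cl)c(C(F)(F)F)c1` gives 101%, compound 2 `O=C(Nc1cccc(-n2cc(-c3ccncc3)c(-c3cc(O)cc(Cl)c3)n2)c1)Nc1ccc(Cl)c(Cl)c1` gives 107%, and compound 3 `COc1cc(Cl)cc(-c2nn(-c3cccc(NC(=O)Nc4ccc(Cl)c(C(F)(F)F)c4)c3)cc2-c2ccncc2)c1` gives 94%. Compound 3 stands lowest of the three numbers, but its nearest neighbour is compound 1, and that gap, a number 7 percentage points lower from compound 1 to compound 3 (within the scatter), sits within the scatter; only the gap to compound 2 lies beyond it, so compound 3 cannot be called the most active on these numbers.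

Compound 4 `COc1cc(Cl)cc(-c2nn(-c3cccc(NC(=O)Nc4ccc(Cl)c(Cl)c4)c3)cc2-c2ccncc2)c1` has not yet been measured. It differs from compound 3 by chloro in place of trifluoromethyl on an aromatic carbon. The same exchange has already been made once on the shared core, from compound 1 to compound 2: a number 6 percentage points higher from compound 1 to compound 2 (within the scatter), a step within the scatter. The other measured step, a number 7 percentage points lower from compound 1 to compound 3 (within the scatter), concerns the methyl on the oxygen; that methyl is common to compound 3 and compound 4 and so does not separate them. On this basis no step beyond the scatter is expected in this assay, with at most a slight drift toward the higher numbers of compound 2.

The value of compound 4 in this assay is estimated at 100%, within a range from 88% to 112%, which means an expected step of a number 6 percentage points higher from compound 3 to compound 4 (within the scatter).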

Compound 4, a percentage reported as activity, at one concentration (the size of the read-out at that concentration, not a potency): 101%
Compound 4: the middle estimate sits 1 percentage points below what was measured, and the stated range covers the measured number.
By their numbers in this assay, from the lowest: compounds 3, 1, 4 and 2 (each within the scatter of the next, the first and the last beyond it).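

In this assay, chloro in place of trifluoromethyl at this position, ortho to a chloro group, can now be read on a second core, the one carrying the methyl on the oxygen, where the step is a number 7 percentage points higher from compound 3 to compound 4 (within the scatter). The exchange thus no longer rests on a single pair, and its two readings agree: the same change on two cores in this assay, a number 6 percentage points higher (within the scatter) from compound 1 to compound 2 and a number 7 percentage points higher (within the scatter) from compound 3 to compound 4, 1 percentage points apart, within the scatter of two such steps. The methyl on the oxygen can now also be read on two cores, with a number 6 percentage points lower from compound 2 to compound 4 (within the scatter) on the 3,4-dichlorophenyl side, and again the two readings agree, each within the scatter, so neither change separates compounds on this read-out: the same change on two cores in this assay, a number 7 percentage points lower (within the scatter) from compound 1 to compound 3 and a number 6 percentage points lower (within the scatter) from compound 2 to compound 4, 1 percentage points apart, within the scatter of two such steps.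

The compounds shown carry only trifluoromethyl or chloro at this position and only hydrogen or methyl on the oxygen, so it remains open whether a nitrile or an amine at this position, or a longer chain on the oxygen, would give a step beyond the scatter. All the numbers also come from the one concentration, so they leave open how these four compounds would compare at higher concentrations.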